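Trimming the aryl arm of an alpha-ketooxazole to fluorine

The source may hold more compounds than are shown below. What is called first, only, known or untested is meant among the compounds shown, and "the series" means these compounds.

Compounds measured so far:
compound 1 `Cc1cccnc1-c1cnc(C(=O)CCCCCCc2ccccc2)o1`, 15 nM
compound 2 `COc1ncc(-c2cnc(C(=O)CCCCCCc3ccccc3)o2)c(OC)n1`, 26 nM
compound 3 `O=C(CCCCCCc1ccccc1)c1ncc(-c2cnc(C(=O)CCCCCCc3ccccc3)o2)o1`, 3500 nM

In an assay (Rattus norvegicus) for inhibition of Fatty-acid amide hydrolase 1 (Homo sapiens) (on this read-out higher numbers stand for weaker inhibition and lower numbers for stronger inhibition), compound 1 gives the lowest number of the three. Compound 2 sits within the scatter of it, so the two cannot be ranked; compound 3 lies far beyond the scatter, so compound 1 is clearly stronger than compound 3. Compound 4 `O=C(CCCCCCc1ccccc1)c1ncc(F)o1` has not yet been measured. It differs from compound 1 in one place: fluoro in place of 3-methylpyridin-2-yl on an aromatic carbon. Among the compounds with values here, no measured pair shows this change, so its size is unknown. Removing the whole six-membered aromatic ring is expected to cost potency, a step of a 53-fold higher number from compound 1 to compound 4 (1.73 log units; beyond the scatter) beyond the scatter. Compound 4 is therefore estimated at 800 nM, within 200 nM to 3000 nM.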

Compound 4, inhibition constant: 30 nM
Compound 4: the middle estimate sits 27-fold (1.43 log units) above what was measured; the measured number lies below the stated range.
By their numbers in this assay, from the lowest: compounds 1, 2 and 4 (each within the scatter of the next); then compound 3.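

In this assay, putting fluoro in place of 3-methylpyridin-2-yl gives a 2.0-fold higher number from compound 1 to compound 4 (0.30 log units; within the scatter) so the two compounds cannot be ranked. On this aromatic carbon next to the ring oxygen, the whole six-membered aromatic ring can therefore give way to a single fluorine atom without a change that can be told from the scatter. Nothing available here explains this result. As far as these compounds go, whether a hydrogen, a chlorine atom or an amine on the same carbon would read alike remains open, and so does whether the same holds with a longer chain on the ketone.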